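Hydroxy to 2-aminophenyl on compound 2

The source may report more compounds than this note shows. Statements on the series, on what has been measured and on what is new or still open speak of the compounds shown alone.

Compound 1 `Nc1nc(NCc2ccc(OCCCCC(=O)NO)cc2)nc2nc(-c3ccco3)nn12` gives "not determined" (no result reported)
Compound 2 `Nc1nc(NCCOc2ccc(C(=O)NO)cc2)nc2nc(-c3ccco3)nn12` gives > 100000 nM

In a functional assay on CT26 cells (Mus musculus) for antiproliferative activity, read by CCK-8 assay, with a stated time of 72 h (a lower number here means a stronger inhibitor of growth, a higher number a weaker inhibitor of growth), compound 2 gives > 100000 nM as a limit of the assay and not a number. Going by the values given here, compound 1 has no result, so no measured step is available to size the next change. Compound 3 (`Nc1ccccc1NC(=O)c1ccc(OCCNc2nc(N)n3nc(-c4ccco4)nc3n2)cc1`) carries 2-aminophenyl in place of hydroxy on an amide-type nitrogen. A modest gain in growth inhibition is expected, with an estimated change of an at least 2.5-fold lower number from compound 2 to compound 3 (0.39 log units; beyond the scatter) and a real chance that the result stays at the limit. Compound 3 is expected at 40000 nM (range 8000 nM to 100000 nM).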

Compound 3, concentration for 50% growth inhibition: 32400 nM
Beside the measured number, compound 3's estimate is 1.2-fold (0.09 log units) above it; low and high end bracket the measured number.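

On the amide-type nitrogen, 2-aminophenyl in place of hydroxy brings the series to a single number in this assay, with an at least 3.0-fold lower number from compound 2 to compound 3 (0.48 log units; beyond the scatter). This position therefore responds to the change, but the step gives only a lower bound on its size, because one end is a limit of the assay and not a number: the limit of > 100000 nM in this assay, at which 1 of the 3 values shown sits.

Open, going by these compounds, is whether a plain phenyl on the same nitrogen would give a comparable result, which would show how much depends on the amine of the 2-aminophenyl group. Also open, on these data alone, is how a longer chain to the amide carbonyl would act with 2-aminophenyl in place.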